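This account rests on a few compounds, and the source may have more. Where it says the series, first, only, none or still open, it means among the compounds named here.

In an ADME assay on HeLa Rh cells (Homo sapiens) for cytotoxicity, read by microscopy (on this read-out higher numbers stand for lower toxicity in this test and lower numbers for higher toxicity in this test), compound 1, `COc1cc(CC(O)c2ccc(-c3ccc(C)cc3)cc2)c([N+](=O)[O-])cc1OC`, gives 4700 nM. Compound 2, `COc1ccc(-c2ccc(C(O)Cc3cc(OC)c(OC)cc3[N+](=O)[O-])cc2)cc1`, reaches only a limit of the test in this assay, > 244000 nM. Within the data shown here, the single change from one to the other, methoxy in place of methyl on an aromatic carbon, brings an at least 51-fold higher number from compound 1 to compound 2 (1.71 log units; beyond the scatter). Where compound 2 stands is therefore known only as a limit, (the limit of > 244000 nM in this assay, at which 1 of the 2 values shown sits).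

Compound 3, `COc1cc(CC(O)c2ccc(-c3ccccc3CO)cc2)c([N+](=O)[O-])cc1OC`, is not yet measured. It differs from compound 2 in one place: 2-(hydroxymethyl)phenyl in place of 4-methoxyphenyl on an aromatic carbon. Among the measured compounds shown here, no measured step covers a change of this kind; the one step known here swaps methyl for methoxy, which does not bear on exchanging a whole 4-methoxyphenyl for a 2-(hydroxymethyl)phenyl. The starting point itself is uncertain because compound 2 gives only the limit > 244000 nM in this assay. Compound 3 is therefore expected to show an at least 2.4-fold lower number from compound 2 to compound 3 (0.38 log units; beyond the scatter), with wide uncertainty in either direction. In this assay compound 3 is estimated at 100000 nM, between 10000 nM and 250000 nM.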

Compound 3, half-maximal cytotoxic concentration: 24000 nM
For compound 3 the middle estimate is 4.2-fold (0.62 log units) above the measured one; low and high end bracket the measured number.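

Compound 3 has the same atoms as compound 2, joined differently, yet in this assay replacing 4-methoxyphenyl with 2-(hydroxymethyl)phenyl gives an at least 10-fold lower number from compound 2 to compound 3 (1.00 log units; beyond the scatter), so this position responds not only to methyl against methoxy but also to how the same atoms are arranged in the group. The change from 4-methylphenyl to 2-(hydroxymethyl)phenyl gives a 5.1-fold higher number from compound 1 to compound 3 (0.71 log units; beyond the scatter), which places compound 3 on the less toxic side of compound 1 on this read-out, while it remains on the more toxic side of compound 2. The step from compound 2 gives only a minimum size, because compound 2 stands at a limit of the test: the limit of > 244000 nM in this assay, at which 1 of the 3 values shown sits.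

The data do not separate the effect of where the substituent sits on the outer ring from the effect of which substituent it is, and a 2-methoxyphenyl or a 4-(hydroxymethyl)phenyl at this place would change only one of the two. As far as these compounds go, whether an amine or a carboxylic acid on that ring would bring the number closer to compound 1 or to compound 2 also remains open.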